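Adding one fluoro to compound 3

The source may report more compounds than this note shows. Statements on the series, on what has been measured and on what is new or still open speak of the compounds shown alone.

- compound 1 (`COc1c(N2CCN(CN3C(=O)C(=O)c4cc(F)ccc43)CC2)c(F)cc2c(=O)c(C(=O)O)cn(C3CC3)c12`): 70600 nM
- compound 2 (`CCO/N=C1\C(=O)N(CN2CCN(c3c(F)cc4c(=O)c(C(=O)O)cn(C5CC5)c4c3OC)CC2)c2ccc(F)cc21`): 85800 nM
- compound 3 (`CO/N=C1\C(=O)N(CCN2CCN(c3c(F)cc4c(=O)c(C(=O)O)cn(C5CC5)c4c3OC)CC2)c2ccccc21`): 306000 nM

In an ADME assay on Vero cells (Chlorocebus sabaeus) for cytotoxicity, read by MTT assay, with a stated time of 72 h (a higher number here means that more compound is tolerated, a lower number that less compound is tolerated), compound 3 gives 306000 nM as the highest of the three numbers, beyond the scatter from both others. Compound 4 (`CO/N=C1\C(=O)N(CCN2CCN(c3c(F)cc4c(=O)c(C(=O)O)cn(C5CC5)c4c3OC)CC2)c2ccc(F)cc21`) is compound 3 with one change (fluoro in place of hydrogen on an aromatic carbon): fluoro in place of hydrogen on an aromatic carbon. Within the data shown here, no measured pair shows this change alone. Compound 1 at 70600 nM and compound 2 at 85800 nM also carry that fluoro, yet differ from compound 3 elsewhere too, which makes them only a weak guide. The expected change is a moderate fall, estimated as a 2.0-fold lower number from compound 3 to compound 4 (0.31 log units; beyond the scatter) and possibly close to the scatter. For compound 4 the estimate is 150000 nM as the expected value, with an expected range from 70000 nM to 320000 nM in this assay once measured.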

Compound 4, half-maximal cytotoxic concentration: 12800 nM
Estimate against measurement, compound 4: 12-fold (1.07 log units) above, and the stated range ends above it.
By their numbers in this assay, from the lowest: compound 4; then compounds 1 and 2 (each within the scatter of the next); then compound 3.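

Among these compounds, compound 3 and compound 4 differ only in this one place, so this is the first clean reading of the change: fluoro in place of hydrogen on this aromatic carbon gives a 24-fold lower number from compound 3 to compound 4 (1.38 log units; beyond the scatter) in this assay. Compound 1 and compound 2 could not show this, since they differ from compound 3 elsewhere too. Nothing at hand explains the size of this step. Open, from the compounds shown here alone, is whether chloro or an amine at this position would lower the number as far, and whether fluoro does the same with a longer chain on the oxime oxygen.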